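From Hydrogen to Chloro on the Shared Core

A few compounds are considered here, and "the series" means these few. Any claim that something is new, unique, unknown or untested is made for them only; others in the source may bear on it.

In a functional assay on SW480 cells (Homo sapiens) for antiproliferative activity, read by MTT assay, with a stated time of 48 h (a higher number here means a weaker inhibitor, a lower number a stronger inhibitor), compound 3 `CCCCCC(CCO)n1cnc2c(Cl)ncnc21` gives > 50000 nM, which is a limit of the assay and not a number.

Compound 4 `CCCCCC(CCO)n1cnc2c(Cl)nc(Cl)nc21` differs from it by one change: chloro in place of hydrogen on an aromatic carbon. This puts chloro in place of hydrogen on an aromatic carbon, between two ring nitrogen atoms.

Two measured compounds bear on this change. Compound 2 `CCCCCC(CCO)n1cnc2c(Cl)nc(F)nc21` carries fluoro at that place and gives 7440 nM in this assay. Its step is the only measured one at this carbon: an at least 6.7-fold higher number from compound 2 to compound 3 (0.82 log units; beyond the scatter), with hydrogen in place of fluoro. Replacing the halogen with hydrogen therefore cost at least modest ground, and the reverse kind of change, a halogen in place of hydrogen, is expected to lead to a lower number.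

Compound 1 `CCCCC(CCO)n1cnc2c(Cl)nc(Cl)nc21` has chloro at that place but a different chain, and it gives 30900 nM in this assay. Among the measured compounds shown here, this value offers a cautious upper guide, since no measured step isolates chloro itself.

A step of similar size is therefore anticipated, towards stronger inhibition. The estimated change is an at least 4.1-fold lower number from compound 3 to compound 4 (0.61 log units; beyond the scatter).

For compound 4 the expected value is 12000 nM, with an estimated range of 4000 nM to 35000 nM.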

Compound 4, half-maximal inhibitory concentration: 6010 nM
Compound 4: middle estimate off by 2.0-fold (0.30 log units), on the high side; low and high end bracket the measured number.
By their numbers in this assay, from the lowest: compounds 4 and 2 (each within the scatter of the next); then compound 1. At a limit, above all of these: compound 3.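

At this carbon between two ring nitrogen atoms, chloro now has a measured step of its own on the shared core: chloro in place of hydrogen gives an at least 8.3-fold lower number from compound 3 to compound 4 (0.92 log units; beyond the scatter), so the loss seen earlier on removing fluoro is matched by a gain on adding chloro. The two halogens are not told apart here, since chloro in place of fluoro gives a 1.2-fold lower number from compound 2 to compound 4 (0.09 log units; within the scatter), and in this assay the position shows a need for a halogen rather than a preference for one of these two. Among the compounds shown here, the chain also counts with chloro held fixed at this carbon, which no earlier step could show: methyl in place of hydrogen on a saturated chain carbon, five bonds along the chain from an aromatic nitrogen, gives a 5.1-fold lower number from compound 1 to compound 4 (0.71 log units; beyond the scatter).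

On these data alone, the full size of the step from hydrogen stays open, because compound 3 stands at a limit and not at a number: the limit of > 50000 nM in this assay, at which 1 of the 4 values shown sits. Also open is whether bromo, an amine or a methoxy group at this carbon would hold the number of compound 4, and whether a longer chain would lower it further.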